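The source may hold more compounds than are shown below. What is called first, only, known or untested is meant among the compounds shown, and "the series" means these compounds.

Measured compounds and their values:

- Compound 1, `C[C@@H](NC(=O)Nc1ccccc1C(C)(C)C)c1ccccc1`, in an ADME assay on the whole organism with Oryza sativa as the target, tested at 0.1 uM (a higher number here means a weaker effect of the compound at the concentration tested, a lower number a stronger effect), compound 1 gives 100%.
- Compound 2, `C[C@H](NC(=O)Nc1ccccc1C(C)(C)C)c1ccccc1`, in this assay compound 2 gives 101%.
- Compound 3, `C[C@@H](NC(=O)Nc1ccc(F)cc1)c1ccccc1`, in this assay compound 3 gives 98%.

All three numbers sit close together, and compound 2 stands within the usual scatter of both compound 1 and compound 3. Going by the values given here, the one measured step, a number 1 percentage points higher from compound 1 to compound 2 (within the scatter), is the smallest possible kind of change: the fact that compounds 1 and 2 differ only in the configuration as drawn, and the read-out did not move beyond the scatter.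

Compound 4, `C[C@H](NC(=O)Nc1ccccc1Cl)c1ccccc1`, has not yet been measured in this assay. Its difference from compound 2 is chloro in place of tert-butyl on an aromatic carbon. Among the compounds with values here, no measured step swaps the tert-butyl for anything else, so the stereo step gives no direct guidance, and compound 3, which carries a fluoro on a different part of the shared core, sits within the scatter of compound 2. Within the data shown here, with every number so far at the top of the scale, the expectation for compound 4 is a step of about a number 2 percentage points lower from compound 2 to compound 4 (within the scatter), not beyond the scatter. Compound 4 is therefore estimated at 99%, with a range from 92% to 106%.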

Compound 4, a percentage reported as activity, at one concentration (the size of the read-out at that concentration, not a potency): 99%
For compound 4 middle estimate and measured number coincide at the digits printed; measured number inside the range.
By their numbers in this assay, from the lowest: compounds 3, 4, 1 and 2 (each within the scatter of the next).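

Replacing tert-butyl with chloro on this aromatic carbon gives a number 2 percentage points lower from compound 2 to compound 4 (within the scatter) in this assay. This is the first step shown that exchanges one group for another, rather than altering only the configuration, and the read-out stays within the scatter even though a group of 4 heavy atoms gives way to one of 1 heavy atom. Nothing available explains why these two groups read alike.

No compound shown stands beyond the scatter of another in this assay, so it remains open whether any change to the shared core can move this read-out at all. A methoxy group, an amine or a carboxylic acid on this same aromatic carbon would extend the comparison to groups of a different kind.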